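Sec-butyl for cyclohexyl at a limit-bound series

This account rests on a few compounds, and the source may have more. Where it says the series, first, only, none or still open, it means among the compounds named here.

Compound 1 `COc1cc(/C=C/C(=O)/C=C(/C=C/c2ccc(OC(C)=O)c(OC)c2)NC2CCCCC2)ccc1OC(C)=O` has no numerical reading in an ADME assay on Caco-2 cells (Homo sapiens) for inhibition, read by sulforhodamine B assay, with a stated time of 72 h; a lower number here means a stronger inhibitor, a higher number a weaker inhibitor: compound 1 gives only a limit, > 25000 nM. Compound 2 `C=CCNC(=C\C(=O)/C=C/c1ccc(O)c(OC)c1)/C=C/c1ccc(O)c(OC)c1` also gives only a limit, with compound 2 at > 25000 nM. Compound 3 `CCC(C)NC(=C\C(=O)/C=C/c1ccc(O)cc1)/C=C/c1ccc(O)cc1` is likewise a limit, with compound 3 at > 25000 nM. Within the data shown here, the series so far stands at the limit of > 25000 nM in this assay, at which 3 of the 3 values shown sit. Compound 4 `CCC(C)NC(=C\C(=O)/C=C/c1ccc(OC(C)=O)c(OC)c1)/C=C/c1ccc(OC(C)=O)c(OC)c1` is still unmeasured and differs from compound 1 by sec-butyl in place of cyclohexyl on an amine nitrogen. Among the measured compounds shown here, no measured step is available to size this change, so the step expected in this assay is none beyond the scatter, and a number no higher from compound 1 to compound 4 (the limit leaves the size open) is the estimated size. For compound 4 the estimated value is 25000 nM, with an expected range from 10000 nM to 50000 nM.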

Compound 4, half-maximal inhibitory concentration: > 25000 nM
Compound 4: no number, only a limit; the forecaster's own chance of this, stated with the estimate: 75%; the middle value sits exactly at the limit.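

Compound 1 and compound 4 both give only limits, so no step can be read for sec-butyl in place of cyclohexyl on an amine nitrogen. The size of that change and any numerical reading for the series stay open: the limit of > 25000 nM in this assay, at which 4 of the 4 values shown sit.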